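A Pyrazole Replaces the Phenyl Ring of Compound 3

The compounds below may be only part of what the source reports. "The series", "measured", "known", "first", "only" and "open" are said of these compounds alone.

Three compounds built on one shared core were tested in a functional assay on MGC-803 cells (Homo sapiens) for inhibition, read by sulforhodamine B assay, with a stated time of 72 h, tested at 10 uM; a higher number here means more inhibition at the concentration tested (going by the name of the read-out), a lower number less inhibition. Compound 1 `Cc1cc(Nc2ccc(C(=O)/C=C/c3ccc(Br)cn3)cc2)n2nc(SCc3nc4ccccc4[nH]3)nc2n1` gives 96.8% in this assay, and compound 2 `Cc1cc(Nc2ccc(C(=O)/C=C/c3ccccc3)cc2)n2nc(SCc3nc4ccccc4[nH]3)nc2n1` gives 94.5%. Compound 3 `Cc1cc(Nc2ccccc2)n2nc(SCc3nc4ccccc4[nH]3)nc2n1`, which carries only a phenyl on the ring nitrogen, gives 22.4% and stands lowest of the three numbers, well apart from both others. The step of a number 74.4 percentage points lower from compound 1 to compound 3 (beyond the scatter) and the step of a number 72.1 percentage points lower from compound 2 to compound 3 (beyond the scatter) are both large, whereas the step of a number 2.3 percentage points lower from compound 1 to compound 2 (within the scatter) lies within the scatter.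

Compound 4 `Cc1cc(Nc2cc(-c3ccccc3)[nH]n2)n2nc(SCc3nc4ccccc4[nH]3)nc2n1` has not yet been measured. It differs from compound 3 in this way: 5-phenyl-1H-pyrazol-3-yl in place of phenyl on a nitrogen on an aromatic ring. Among the measured compounds shown here, none of the measured steps touches this place. For the measured compounds named here, the two large steps concern the removal of a chain from an aromatic carbon, and the one small step swaps one aromatic ring for another on a chain carbon. Going by the values given here, the substituent on the ring nitrogen therefore has no measured precedent, and the chain that drove the large steps is still absent in compound 4.

The account expects only a modest change in this assay, and the expected step is a number 7.6 percentage points higher from compound 3 to compound 4 (within the scatter). The estimate for compound 4 is 30%, with a range from 10% to 60%.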

Compound 4, a percentage reported as inhibition, at one concentration (the size of the read-out at that concentration, not a potency): 78.4%
Beside the measured number, compound 4's estimate is 48.4 percentage points below it; measured number above the stated range.
By their numbers in this assay, from the lowest: compound 3; then compound 4; then compounds 2 and 1 (each within the scatter of the next).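

In this assay, the substituent on the nitrogen on an aromatic ring proves to be a position of strong response, with a number 56 percentage points higher from compound 3 to compound 4 (beyond the scatter). Until now, only the (2-phenylethenyl)carbonyl and (2-(5-bromopyridin-2-yl)ethenyl)carbonyl chains had been linked to a large step, yet compound 4 carries neither chain, so a large rise from compound 3 does not depend on them. The change replaces phenyl with the larger 5-phenyl-1H-pyrazol-3-yl, which brings a five-membered aromatic ring, a hydrogen-bond donor and a hydrogen-bond acceptor, but nothing available explains why the number rises.

The compounds shown do not separate the contribution of the pyrazole ring from that of its phenyl, a question that an unsubstituted 1H-pyrazol-3-yl or a 5-methyl-1H-pyrazol-3-yl group on the same nitrogen would address. They also leave open what would happen if compound 4 carried a (2-phenylethenyl)carbonyl chain as well, and, with a read-out taken at one concentration, how the potency of compound 4 compares with that of compound 3.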